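The source may hold more compounds than are shown below. What is called first, only, known or untested is meant among the compounds shown, and "the series" means these compounds.

In a functional assay on HT cells (Homo sapiens) for antiproliferative activity, read by fluorescence, with a stated time of 72 h (a higher number here means a weaker inhibitor of growth, a lower number a stronger inhibitor of growth), compound 1 `CSc1nc(NCc2ccc(-c3ccccn3)cc2)c2[nH]nc(C(C)C)c2n1` gives 783 nM and compound 2 `CC(C)c1n[nH]c2c(NCc3ccc(-c4ccccn4)cc3)nc(SC3CCCCC3O)nc12` gives 636 nM, so the two values stand within the scatter of each other. Compound 3 `CNCCSc1nc(NCc2ccc(-c3ccccn3)cc2)c2[nH]nc(C(C)C)c2n1` changes the same place again: 2-(methylamino)ethyl in place of 2-hydroxycyclohexyl on a sulfur. In words, 2-(methylamino)ethyl stands in place of 2-hydroxycyclohexyl on a sulfur. Within the data shown here, only one measured step bears on this place, a 1.2-fold lower number from compound 1 to compound 2 (0.09 log units; within the scatter), with 2-hydroxycyclohexyl in place of methyl on a sulfur. That single step shows one exchange on the sulfur that left the value within the scatter. Among the measured compounds shown here, no measured compound carries 2-(methylamino)ethyl, so the data offer no direct evidence for it, and the expected range stays wide. The expected step is a 1.3-fold lower number from compound 2 to compound 3 (0.10 log units; within the scatter), which means no change beyond the scatter is expected. In this assay the estimate for compound 3 is 500 nM, with an expected range from 150 nM to 1500 nM.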

Compound 3, concentration for 50% growth inhibition: 56 nM
For compound 3 the middle estimate is 8.9-fold (0.95 log units) above the measured one; the whole stated range lies above it.
By their numbers in this assay, from the lowest: compound 3; then compounds 2 and 1 (each within the scatter of the next).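

In this assay, the group on this sulfur can move the number a long way: 2-(methylamino)ethyl in place of 2-hydroxycyclohexyl gives an 11-fold lower number from compound 2 to compound 3 (1.06 log units; beyond the scatter), and the same chain set against methyl gives a 14-fold lower number from compound 1 to compound 3 (1.15 log units; beyond the scatter). The earlier exchange, from methyl to 2-hydroxycyclohexyl, stayed within the scatter, so among the three groups shown only 2-(methylamino)ethyl stands apart. Nothing at hand offers an explanation for this large step.

The compounds shown leave open whether the nitrogen or the open chain matters, as 2-(methylamino)ethyl differs from 2-hydroxycyclohexyl in both its heteroatom and the loss of the ring. A 2-hydroxyethyl group, a 2-aminoethyl group, a 2-(dimethylamino)ethyl group or a 3-(methylamino)propyl group on the same sulfur would begin to separate these readings.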